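The compounds below may be only part of what the source reports. "The series", "measured", "known", "first", "only" and "open" are said of these compounds alone.

Compound 1 `OC[C@H](NC[C@H]1NC[C@H](O)[C@@H]1O)c1ccc(-c2ccccc2)cc1` is the starting point here. In a functional assay on U-266 cells (Homo sapiens) for cytotoxicity, read by colorimetric assay, with a stated time of 72 h (a higher number here means a weaker inhibitor, a lower number a stronger inhibitor), compound 1 gives > 200000 nM, which is a limit of the assay rather than a number. Compound 2 `OC[C@H](NC[C@H]1NC[C@H](O)[C@@H]1O)c1ccc(-c2ccc(C(F)(F)F)cc2)cc1` carries a trifluoromethyl where compound 1 has a hydrogen on an aromatic carbon, and in this assay compound 2 gives 50000 nM. Among the compounds with values here, that change gives an at least 4.0-fold lower number from compound 1 to compound 2 (0.60 log units; beyond the scatter), the only measured step in this set, and its size is bounded by the limit of > 200000 nM in this assay, at which 1 of the 2 values shown sits, for compound 1.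

Compound 3 `OC[C@H](NC[C@H]1NC[C@H](O)[C@@H]1O)c1ccc(-c2ccsc2)cc1` differs from compound 1 in another way: thiophen-3-yl in place of phenyl on an aromatic carbon. Within the data shown here, no measured step exchanges one aromatic ring for another, so the step from compound 1 to compound 2 offers no direct guide for this change. With compound 1 known only as a limit, there is no number to move from, and the expectation is that compound 3 stays close to compound 1, with a real chance that this assay again reports only a limit. The estimate for compound 3 in this assay is therefore 200000 nM, within 60000 nM to 500000 nM, which means an expected step of a number no higher from compound 1 to compound 3 (the limit leaves the size open).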

Compound 3, half-maximal inhibitory concentration: "not active" (no number reported)
No number was reported for compound 3, so the estimate cannot be set against anything.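

Compound 3 is reported as "not active" in this assay, with no number, so no new step can be read between compound 1 and compound 3. The compounds shown leave open whether thiophen-3-yl in place of phenyl changes the result at all, and how far apart compound 1 and compound 3 truly lie.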